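Methyl Relocated and Methoxy Removed on a Shared Core

The compounds below may be only part of what the source reports. "The series", "measured", "known", "first", "only" and "open" are said of these compounds alone.

Measured compounds:
compound 1, `Cc1ccc(Nc2ccc3c(c2)C(=O)N(C2CCC(=O)NC2=O)C3=O)cc1`, gives 5%
compound 2, `COc1ccc(Nc2ccc3c(c2)C(=O)N(C2CCC(=O)NC2=O)C3=O)cc1`, gives 29%

Both compounds share one core and differ only in the group carried on the nitrogen attached to the aromatic ring. In an assay on FRT-Jurkat cells for inhibition of nuclear factor NF-kappa-B complex (Homo sapiens), read by flow cytometry, with a stated time of 24 h, tested at 10 uM (a higher number here means more inhibition at the concentration tested (going by the name of the read-out), a lower number less inhibition), compound 1 gives 5%, while compound 2 gives 29%. Going by the values given here, the single step between them, a number 24 percentage points higher from compound 1 to compound 2 (beyond the scatter), is the only comparison available, and it places compound 2 highest of the two numbers so far, with compound 1 the nearest and lower.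

Compound 3, `Cc1ccccc1Nc1ccc2c(c1)C(=O)N(C1CCC(=O)NC1=O)C2=O`, has not yet been measured. Its change from compound 2 is 2-methylphenyl in place of 4-methoxyphenyl on a nitrogen on an aromatic ring. This change does two things at once: the methoxy leaves and a methyl returns, and the methyl now sits at a different position of the ring than in compound 1. The measured step of a number 24 percentage points higher from compound 1 to compound 2 (beyond the scatter) bears on the first part and suggests that losing the methoxy should lower the number, since compound 1 with a methyl sits well below compound 2. Nothing measured bears on the change of position.

For compound 3 the estimated result is therefore a fall, a number 17 percentage points lower from compound 2 to compound 3 (beyond the scatter), to about 12%, within 0% to 30%.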

Compound 3, a percentage reported as inhibition, at one concentration (the size of the read-out at that concentration, not a potency): 2%
Beside the measured number, compound 3's estimate is 10 percentage points above it; low and high end bracket the measured number.
By their numbers in this assay, from the lowest: compounds 3 and 1 (each within the scatter of the next); then compound 2.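

In this assay the change to 2-methylphenyl from 4-methoxyphenyl, on a nitrogen on an aromatic ring, gives a number 27 percentage points lower from compound 2 to compound 3 (beyond the scatter) and so leaves compound 2 clear of both compounds that carry a methyl. The change to 2-methylphenyl from 4-methylphenyl gives a number 3 percentage points lower from compound 1 to compound 3 (within the scatter) and so adds what the first two compounds could not show: moving the methyl from one of these two places to the other makes no difference this read-out can separate, and both methylphenyl compounds sit near the bottom of its range. Nothing shown here explains why the methoxy compound stands apart from the two methyl compounds.

The three compounds leave open whether the oxygen of the methoxy matters or whether other groups in its place would do as well, such as an amine, a carboxylic acid or a longer chain like ethoxy. They also leave open how far the reading of compound 2 reflects real potency, since each number comes from a single concentration and a full dose-response curve would be needed to say.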